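From phenyl to 4-methylphenyl on a shared core

The source may report more compounds than this note shows. Statements on the series, on what has been measured and on what is new or still open speak of the compounds shown alone.

In a functional assay on HepG2 cells (Homo sapiens) for cytotoxicity, read by MTT assay, with a stated time of 72 h (a higher number here means a weaker inhibitor, a lower number a stronger inhibitor), compound 2 `O=C(Nc1ccc(Oc2ncnc3ccsc23)c(F)c1)c1nn(-c2ccccc2)ccc1=O` gives 13500 nM. Among the compounds with values here, its only measured neighbour is compound 1 `O=C(Nc1ccc(Oc2ncnc3ccsc23)c(F)c1)c1nn(-c2ccc(Br)cc2)ccc1=O`, which in this assay gives 10700 nM; the step of a 1.3-fold higher number from compound 1 to compound 2 (0.10 log units; within the scatter) shows that swapping bromo for hydrogen left the number within the scatter. Compound 3 `Cc1ccc(-n2ccc(=O)c(C(=O)Nc3ccc(Oc4ncnc5ccsc45)c(F)c3)n2)cc1` differs from compound 2 by methyl in place of hydrogen on an aromatic carbon. Within the data shown here, the one measured step concerns the same place on the shared core and was small, so for compound 3 the expected step is a 1.0-fold lower number from compound 2 to compound 3 (0.02 log units; within the scatter). Compound 3 is therefore estimated to give about 13000 nM, in the range 6000 nM to 28000 nM.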

Compound 3, half-maximal inhibitory concentration: 24300 nM
Beside the measured number, compound 3's estimate is 1.9-fold (0.27 log units) below it; low and high end bracket the measured number.
By their numbers in this assay, from the lowest: compounds 1, 2 and 3 (each within the scatter of the next, the first and the last beyond it).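

In this assay, methyl in place of hydrogen gives a 1.8-fold higher number from compound 2 to compound 3 (0.26 log units; within the scatter), so that change alone cannot be told from repeat-measurement noise. Methyl in place of bromo gives a 2.3-fold higher number from compound 1 to compound 3 (0.36 log units; beyond the scatter), a modest step but the first at this position to pass the scatter, which shows that the choice of group here can shift the number measurably. On these data alone, whether an amine or a carboxylic acid at this position would move the number, and in which direction, remains open. Nothing measured here accounts for the difference between bromo and methyl.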